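A few compounds are considered here, and "the series" means these few. Any claim that something is new, unique, unknown or untested is made for them only; others in the source may bear on it.

Compound 1 `CCCc1ccc(NC2=CC(=O)c3c(nc4n3[C@H]3OC[C@@H](O)[C@H]3OC4)C2=O)cc1` is tested in a functional assay on MGC-803 cells (Homo sapiens) for inhibition, read by sulforhodamine B assay (on this read-out higher numbers stand for weaker inhibition and lower numbers for stronger inhibition), where compound 1 gives 1920 nM. Compound 2 `O=C1C=C(Nc2cccc(Cl)c2)C(=O)c2c1nc1n2[C@H]2OC[C@@H](O)[C@H]2OC1` in this assay gives 1770 nM, close to compound 1 and within the usual scatter. Compound 3 `O=C1C=C(NC2CCCC2)C(=O)c2c1nc1n2[C@H]2OC[C@@H](O)[C@H]2OC1` reaches only > 8000 nM, which is a limit of this assay and not a number. Among the compounds with values here, the one measured step, an at least 4.5-fold higher number from compound 2 to compound 3 (0.65 log units; beyond the scatter), rests on (the limit of > 8000 nM in this assay, at which 1 of the 3 values shown sits). Compound 4 `O=C1C(Nc2ccc(Br)cc2)=CC(=O)c2c1nc1n2[C@H]2OC[C@@H](O)[C@H]2OC1` differs from compound 1 by bromo in place of propyl on an aromatic carbon; it keeps the six-membered aromatic ring of carbon only, so that measured step does not bear on it. Within the data shown here, no measured step shows bromo in place of propyl, so for compound 4 only a change within the scatter is expected, a 1.0-fold lower number from compound 1 to compound 4 (0.00 log units; within the scatter). Compound 4 is thus estimated at 1900 nM, between 800 nM and 4500 nM.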

Compound 4, half-maximal inhibitory concentration: 2020 nM
For compound 4 the middle estimate is 1.1-fold (0.03 log units) below the measured one; the range from low to high includes it.
By their numbers in this assay, from the lowest: compounds 2, 1 and 4 (each within the scatter of the next). At a limit, above all of these: compound 3.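

Exchanging 4-propylphenyl for 4-bromophenyl in this assay gives a 1.1-fold higher number from compound 1 to compound 4 (0.02 log units; within the scatter). Within the data shown here, at this position on the aromatic ring, a three-carbon chain and a single bromine atom therefore cannot be told apart, although this is only one exchange. No measured evidence here bears on why the two groups give such similar results. As far as these compounds go, it remains open whether this holds for groups of other kinds at the same position, such as an amine or a carboxylic acid. A chain longer than propyl is also untested by the compounds shown.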